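The compounds below may be only part of what the source reports. "The series", "measured", "known", "first", "only" and "open" are said of these compounds alone.

Three compounds sharing one core have been examined in an assay on isolated protein for inhibition of NEDD8-activating enzyme E1 regulatory subunit (Homo sapiens), read by Western blot, with stated times of 10 min and 30 min, tested at 25 uM; a higher number here means more inhibition at the concentration tested (going by the name of the read-out), a lower number less inhibition. Compound 1 `CCCNC(=O)c1cccc2nc(OCC)n(Cc3ccc(-c4ccccc4-c4nnn[nH]4)cc3)c12` gives 32.6%. Compound 2 `CCOc1nc2cccc(C(=O)Nc3ccc(F)cc3)c2n1Cc1ccc(-c2ccccc2-c2nnn[nH]2)cc1` gives 45.3%, and compound 3 `CCOc1nc2cccc(C(=O)NC(c3ccccc3)c3ccccc3)c2n1Cc1ccc(-c2ccccc2-c2nnn[nH]2)cc1` gives 35.7%. On these numbers compound 2 stands highest of the three, but the nearest number, that of compound 3, lies within the scatter of it, and only the number of compound 1 sits clearly lower. Within the data shown here, the one measured step, a number 12.7 percentage points higher from compound 1 to compound 2 (beyond the scatter), shows the change from a short alkyl group to an aromatic ring on the amide nitrogen raising the read-out modestly.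

Compound 4 `CCOc1nc2cccc(C(=O)NCCCCc3ccccc3)c2n1Cc1ccc(-c2ccccc2-c2nnn[nH]2)cc1` has not yet been measured. It differs from compound 2 in one place: 4-phenylbutyl in place of 4-fluorophenyl on an amide-type nitrogen. The change thus goes back from an aromatic ring directly on the nitrogen to a chain, with the ring set at the far end of that chain. The step from compound 1 to compound 2 bears on this change in reverse, and the values of compound 1 and compound 3, both with non-aromatic carbon on the nitrogen, also lie lower than that of compound 2. A modest fall is therefore expected, of about a number 8.3 percentage points lower from compound 2 to compound 4 (within the scatter), though it may stay within the scatter. The estimate for compound 4 in this assay is 37%, with a range from 25% to 50%.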

Compound 4, a percentage reported as inhibition, at one concentration (the size of the read-out at that concentration, not a potency): 64.6%
Compound 4: middle estimate off by 27.6 percentage points, on the low side, and the stated range ends below it.
By their numbers in this assay, from the lowest: compounds 1, 3 and 2 (each within the scatter of the next, the first and the last beyond it); then compound 4.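

In this assay, the change shows that an aromatic ring set directly on the amide nitrogen is not what gives the highest number at this position: moving the ring to the far end of a chain, as in 4-phenylbutyl, gives a number 19.3 percentage points higher from compound 2 to compound 4 (beyond the scatter). A carbon chain on this nitrogen is therefore not low in itself, as compound 1 alone had seemed to suggest, and adding benzyl to the end of the propyl chain gives a number 32 percentage points higher from compound 1 to compound 4 (beyond the scatter), so among these chain compounds the number goes with the ring at the far end. Nothing available explains why either step takes this direction or this size.

The compounds shown leave open how far the number depends on the length of the link, since they include neither a shorter one such as benzyl or 2-phenylethyl nor a longer one such as 5-phenylpentyl. They also leave open whether a pyridine ring, an amine or a carboxylic acid at the far end of the chain would serve as well as the phenyl ring, or whether a fluorine on that ring would change the number.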